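Trimming a methyl from compound 2 in a cell-killing test

A few compounds are considered here, and "the series" means these few. Any claim that something is new, unique, unknown or untested is made for them only; others in the source may bear on it.

The two measured compounds here share one core and differ at its two ends. Compound 1 `Cc1cc(O)cc(-c2nn(CC#N)cc2-c2ccnc(-c3ccc(Oc4ccccc4)cc3)c2)c1` carries a phenoxy-bearing ring on one side and a hydroxy-methylphenyl ring on the other; in a functional assay on SF-539 cells (Homo sapiens) for inhibition, read by sulforhodamine B assay, with a stated time of 48 h (on this read-out lower numbers stand for higher toxicity in this test and higher numbers for lower toxicity in this test), compound 1 gives 44000 nM. Compound 2 `COc1cc(C)cc(-c2nn(CC#N)cc2-c2ccnc(-c3ccc(N(C)C)cc3)c2)c1` carries a dimethylamino-bearing ring and a methoxy-methylphenyl ring. For compound 2 only a limit is known in this assay, namely > 100000 nM. Compound 2 therefore stands at the edge of what the test can record, a point made plain by the limit of > 100000 nM in this assay, at which 1 of the 2 values shown sits. Going by the values given here, compound 1 shows a number that the test could still resolve, while compound 2 shows only a limit, and since the two differ in two places, no single step between them can be weighed.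

Compound 3 `Cc1cc(O)cc(-c2nn(CC#N)cc2-c2ccnc(-c3ccc(N(C)C)cc3)c2)c1` is compound 2 with one change: hydrogen in place of methyl on an oxygen on an aromatic ring. Among the compounds with values here, no measured step of this kind is available, so the size of the effect in this assay is open; a modest movement toward greater toxicity, or none beyond the scatter, seems equally plausible. Compound 3 is estimated at 80000 nM, within 30000 nM to 200000 nM, which would mean an expected step of an at least 1.2-fold lower number from compound 2 to compound 3 (0.09 log units; that floor lies within the scatter).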

Compound 3, concentration lethal to 50% of the cells: 27300 nM
The estimate for compound 3 lay 2.9-fold (0.47 log units) above the measured number, and the stated range ends above it.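

In this assay, going by these compounds alone, the change from methoxy to hydroxy gives the first readable step at this position, with an at least 3.6-fold lower number from compound 2 to compound 3 (0.56 log units; beyond the scatter) showing that removing this one methyl, with the dimethylamino group held in place, moves the series toward higher toxicity in this test. On these data alone, the value of compound 2 is only a limit, so this step is a floor and the full size of the change remains unknown: the limit of > 100000 nM in this assay, at which 1 of the 3 values shown sits. The other new comparison holds the hydroxy group fixed, and a 1.6-fold lower number from compound 1 to compound 3 (0.21 log units; within the scatter) lies within the scatter, so dimethylamino in place of phenoxy on an aromatic carbon has no effect that can be told apart here.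

The compounds shown do not tell whether the methoxy to hydroxy step would have a similar size with phenoxy in place of dimethylamino, since no methoxy partner of compound 1 appears among them. They also leave open how an ethoxy group or an amine at the same place on the ring would compare with the hydroxy group of compound 3.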